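The source may hold more compounds than are shown below. What is called first, only, known or untested is meant among the compounds shown, and "the series" means these compounds.

Measured so far:
- compound 1, `CCc1ccc(NC(=O)N[C@H](C)c2ccccc2)cc1`, giving 44% in an ADME assay on the whole organism with Oryza sativa as the target, tested at 10 uM; a lower number here means a stronger effect, a higher number a weaker effect of the compound at the concentration tested
- compound 2, `CCc1ccc(NC(=O)N[C@@H](C)c2ccccc2)cc1`, giving 91% in this assay
- compound 3, `C[C@H](NC(=O)Nc1ccccc1C(C)(C)C)c1ccccc1`, giving 100% in this assay

Among these three numbers, compound 1 stands lowest, and both gaps to the other compounds lie beyond the usual scatter, so it shows the strongest effect of the three. The gap to compound 2 is a number 47 percentage points higher from compound 1 to compound 2 (beyond the scatter), and it is striking because the fact that compounds 1 and 2 differ only in the configuration as drawn: the two share every atom and bond and differ only in the configuration as drawn at one saturated chain carbon.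

Compound 4, `CCCCCc1ccc(NC(=O)N[C@H](C)c2ccccc2)cc1`, has not yet been measured. It differs from compound 1 by propyl in place of hydrogen on a saturated chain carbon, two bonds along the chain from an aromatic carbon. Read one bond further out, the ethyl on the aromatic ring of compound 1 becomes a pentyl. Among the compounds with values here, none of the measured steps changes a chain in this way; the only measured step concerns the configuration at the stereocentre, so it gives no direct guide to lengthening the chain. What it does show is that this read-out can swing widely between closely related structures, so a wide range is appropriate.

Within the data shown here, with no comparable step to lean on, compound 4 is expected near 50%, between 20% and 90%. The expected step from compound 1 is a number 6 percentage points higher from compound 1 to compound 4 (within the scatter), which is within the scatter in the middle estimate.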

Compound 4, a percentage reported as activity, at one concentration (the size of the read-out at that concentration, not a potency): 97%
For compound 4 the middle estimate is 47 percentage points below the measured one; the measured number lies above the stated range.
By their numbers in this assay, from the lowest: compound 1; then compounds 2, 4 and 3 (each within the scatter of the next).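

Read as the ethyl on the aromatic ring of compound 1 becoming a pentyl, this change gives in this assay a number 53 percentage points higher from compound 1 to compound 4 (beyond the scatter), so for these two compounds the longer chain goes with a much weaker effect at the concentration tested. Within the data shown here, until now the only step that could be read was a change of configuration at the stereocentre, and this result shows that a change in the chain alone, with that stereocentre as drawn in compound 1 kept, also produces a large step. Nothing measured here explains why the longer chain has this effect.

With only ethyl and pentyl at this place, the compounds shown leave open how the read-out changes at the chain lengths in between, such as a propyl or butyl, and whether a chain ending in a hydroxyl or a carboxylic acid would behave like the pentyl. They also leave open whether the pentyl compound with the stereocentre drawn S, as in compound 2, would give a different number from compound 4.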